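Dithiocarbamate-linked benzamides: varying the piperazine substituent

The source may report more compounds than this note shows. Statements on the series, on what has been measured and on what is new or still open speak of the compounds shown alone.

Measured compounds:
compound 1, `Nc1ccccc1NC(=O)c1ccc(CSC(=S)N2CCN(c3cccnc3)CC2)cc1`: 88.8%
compound 2, `Cc1ccc(N2CCN(C(=S)SCc3ccc(C(=O)Nc4ccccc4N)cc3)CC2)cc1`: 26.4%

In a functional assay on A-375 cells (Homo sapiens) for antiproliferative activity, read by CCK-8 assay, with a stated time of 72 h, tested at 8 uM (a lower number here means a weaker effect, a higher number a stronger effect of the compound at the concentration tested), compound 2 gives 26.4% and stands lowest of the two numbers; the nearest is compound 1, and the step of a number 62.4 percentage points lower from compound 1 to compound 2 (beyond the scatter) is large. Compound 3, `Nc1ccccc1NC(=O)c1ccc(CSC(=S)N2CCN(C3CCCCC3)CC2)cc1`, is not yet measured. Its change from compound 2 is cyclohexyl in place of 4-methylphenyl on an amine nitrogen in a ring. Among the compounds with values here, no measured step swaps an aromatic ring for a non-aromatic one at this position; the only step known, a number 62.4 percentage points lower from compound 1 to compound 2 (beyond the scatter), shows that the group on this nitrogen moves the read-out strongly. The direction for compound 3 therefore cannot be taken from the data, so a wide range is expected around a middle value. Compound 3 is estimated at 40%, range 10% to 75%, meaning an expected step of a number 13.6 percentage points higher from compound 2 to compound 3 (beyond the scatter).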

Compound 3, a percentage reported as inhibition, at one concentration (the size of the read-out at that concentration, not a potency): 89.9%
Compound 3: the middle estimate sits 49.9 percentage points below what was measured; the whole stated range lies below it.
By their numbers in this assay, from the lowest: compound 2; then compounds 1 and 3 (each within the scatter of the next).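

In this assay there is a number 63.5 percentage points higher from compound 2 to compound 3 (beyond the scatter), so an aromatic ring on this amine nitrogen is not needed for a high read-out. With a number 1.1 percentage points higher from compound 1 to compound 3 (within the scatter), cyclohexyl and pyridin-3-yl cannot be told apart. Aromatic pyridin-3-yl and 4-methylphenyl give opposite results. Aromatic versus non-aromatic therefore does not sort these three compounds. No available evidence explains the low read-out of compound 2.

From the compounds shown here alone, it remains open whether that low read-out belongs to the methyl group or to the carbon-only aromatic ring. An unsubstituted phenyl or a 4-methylcyclohexyl on this nitrogen would separate the two.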